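The source may report more compounds than this note shows. Statements on the series, on what has been measured and on what is new or still open speak of the compounds shown alone.

Measured so far:
- Compound 1 `O=C1C(Nc2ccc(I)cc2)=CC(=O)c2c1nc1n2[C@H]2OC[C@@H](O)[C@H]2OC1`: 3890 nM
- Compound 2 `O=C1C=C(NCc2ccccc2)C(=O)c2c1nc1n2[C@H]2OC[C@@H](O)[C@H]2OC1`: > 8000 nM (a limit, not a number)
- Compound 3 `O=C1C=C(Nc2ccccc2F)C(=O)c2c1nc1n2[C@H]2OC[C@@H](O)[C@H]2OC1`: 3640 nM

In a functional assay on MCF7 cells (Homo sapiens) for inhibition, read by sulforhodamine B assay (on this read-out lower numbers stand for stronger inhibition and higher numbers for weaker inhibition), compound 3 gives 3640 nM, which lies within the scatter of compound 1 at 3890 nM. Compound 4 `CCc1ccc(NC2=CC(=O)c3nc4n(c3C2=O)[C@H]2OC[C@@H](O)[C@H]2OC4)cc1` carries 4-ethylphenyl in place of the 2-fluorophenyl of compound 3 on an amine nitrogen: 4-ethylphenyl in place of 2-fluorophenyl on an amine nitrogen. For the measured compounds named here, no measured step covers this exchange. The nearest is an at least 2.1-fold lower number from compound 2 to compound 3 (0.34 log units; beyond the scatter), with 2-fluorophenyl in place of benzyl, and it is a different exchange that gives no direction here. The expected step, a 1.0-fold lower number from compound 3 to compound 4 (0.00 log units; within the scatter), therefore stays within the scatter. The estimate for compound 4 is 3600 nM, expected to fall between 1700 nM and 7500 nM.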

Compound 4, half-maximal inhibitory concentration: 960 nM
Beside the measured number, compound 4's estimate is 3.8-fold (0.57 log units) above it; the measured number lies below the stated range.
By their numbers in this assay, from the lowest: compound 4; then compounds 3 and 1 (each within the scatter of the next). At a limit, above all of these: compound 2.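

For the compounds shown here, on this amine nitrogen, the choice of substituted phenyl matters: in this assay, 4-ethylphenyl in place of 2-fluorophenyl gives a 3.8-fold lower number from compound 3 to compound 4 (0.58 log units; beyond the scatter), a change the earlier compounds did not show. Set against benzyl, the same group gives an at least 8.3-fold lower number from compound 2 to compound 4 (0.92 log units; beyond the scatter). That step starts from compound 2, whose > 8000 nM is a limit, not a number.

Both the substituent and its place on the phenyl ring change in this step, so the compounds shown cannot separate the two. From the compounds shown here alone, whether a longer chain than ethyl, or a carboxylic acid in its place, would keep this gain remains open.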